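A Nitro Swap Within a Narrow Cytotoxicity Range

This account rests on a few compounds, and the source may have more. Where it says the series, first, only, none or still open, it means among the compounds named here.

Within the data shown here, in an ADME assay on L6 cells (Rattus norvegicus) for cytotoxicity, read by resazurin assay, with a stated time of 72 h (on this read-out lower numbers stand for stronger inhibition and higher numbers for weaker inhibition), three compounds sharing one core have numbers so far. Compound 1 `O=C(NC(=O)c1ccccc1O)c1ccc(F)cc1` gives 38 ug/mL, compound 2 `O=C(NC(=O)c1ccccc1O)c1ccc(OC(F)(F)F)cc1` gives 84 ug/mL and compound 3 `N#Cc1ccc(C(=O)NC(=O)c2ccccc2O)cc1` gives 55 ug/mL. Compound 3 lies within the scatter of both others, with a 1.4-fold higher number from compound 1 to compound 3 (0.16 log units; within the scatter) on one side and a 1.5-fold lower number from compound 2 to compound 3 (0.18 log units; within the scatter) on the other. Only a 2.2-fold higher number from compound 1 to compound 2 (0.34 log units; beyond the scatter) passes beyond the scatter, and that step is modest.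

Compound 4 `O=C(NC(=O)c1ccccc1O)c1ccc([N+](=O)[O-])cc1` comes next, with nitro in place of cyano on an aromatic carbon, para to a large group (nitro in place of cyano on an aromatic carbon). Among the measured compounds shown here, no measured compound carries nitro, so no step shows this exchange directly. The closest evidence is the three exchanges already measured on that aromatic carbon, each replacing one group with another. Two of them stay within the scatter, and the third only just leaves it. On that evidence, only a small shift is expected in this assay, with no firm direction. The estimated change is a 1.1-fold lower number from compound 3 to compound 4 (0.06 log units; within the scatter), so no step beyond the scatter is expected. For compound 4 the expected value is 48 ug/mL, with an estimated range of 22 ug/mL to 100 ug/mL.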

Compound 4, half-maximal inhibitory concentration: 53 ug/mL
Compound 4: middle estimate off by 1.1-fold (0.04 log units), on the low side, within the range that was stated.
By their numbers in this assay, from the lowest: compounds 1, 4, 3 and 2 (each within the scatter of the next, the first and the last beyond it).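

In this assay the nitro group, which has more heavy atoms and more hydrogen-bond acceptors than the cyano it replaces, gives a 1.0-fold lower number from compound 3 to compound 4 (0.02 log units; within the scatter) and so leaves this aromatic carbon para to a large group essentially unmoved by this exchange. Among these compounds, compound 4 also sits within the scatter of the other two compounds, with a 1.6-fold lower number from compound 2 to compound 4 (0.20 log units; within the scatter) and a 1.4-fold higher number from compound 1 to compound 4 (0.14 log units; within the scatter), which shows that nitro can be read directly against all three earlier groups without opening a new step beyond the scatter, and the only step beyond it remains a 2.2-fold higher number from compound 1 to compound 2 (0.34 log units; beyond the scatter) as the one exception among the four compounds. Nothing given here measures any property that could account for these numbers, so the closeness of the values stays a plain observation.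

The compounds shown leave open whether the values would remain this close with a group of a different kind on this aromatic carbon, such as an amine, a carboxylic acid or a longer alkyl chain. They also leave open how any of these groups would read in this assay at another place on the ring or with a change elsewhere in the shared core.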